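Inactive pyrazoline series: a further methoxy group on one ring

The source may report more compounds than this note shows. Statements on the series, on what has been measured and on what is new or still open speak of the compounds shown alone.

Four compounds share one core. Compound 1 `Clc1ccc(C2CC(c3ccccc3)=NN2c2ccc(-c3ccccc3)nn2)cc1` carries an unsubstituted phenyl on one end. Compound 2 `COc1ccc(C2=NN(c3ccc(-c4ccccc4)nn3)C(c3ccc(Cl)cc3)C2)cc1` differs from it by methoxy in place of hydrogen on an aromatic carbon. Compound 3 `COc1ccc(C2=NN(c3ccc(-c4ccccc4)nn3)C(c3ccc(OC)cc3)C2)cc1` differs from compound 2 at the other ring. Compound 4 `COc1ccc(C2=NN(c3ccc(-c4ccccc4)nn3)C(c3ccc(OC)cc3OC)C2)cc1` is not yet measured.

In a functional assay on A549 cells (Homo sapiens) for antiproliferative activity, read by MTT assay, with a stated time of 24 h (on this read-out lower numbers stand for stronger inhibition and higher numbers for weaker inhibition), compound 1 gives 100000 nM. In this assay compound 2 gives 100000 nM, and the step of no change at the digits printed from compound 1 to compound 2 (within the scatter). For compound 3 this assay reports only a limit, > 100000 nM. The step of a number no lower from compound 2 to compound 3 (the limit leaves the size open). The fact that the limit of > 100000 nM in this assay, at which 1 of the 3 values shown sits, marks where the upper edge of the measurable range lies in this series.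

The change from compound 3 to compound 4 is methoxy in place of hydrogen on an aromatic carbon. It is the same kind of change as from compound 1 to compound 2, yet not the same: there the entering group sat para to a large group, here it sits ortho to a large group and meta to a methoxy group. The difference between the core of compound 1 and the core of compound 3 is not broken down here.

Given that the earlier step of this kind produced no change within the scatter, compound 4 is expected to show a number no higher from compound 3 to compound 4 (the limit leaves the size open). The estimate for compound 4 in this assay is 100000 nM, with a likely span from 50000 nM to 200000 nM, and most probably the assay will again report only a limit.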

Compound 4, half-maximal inhibitory concentration: 100000 nM
For compound 4 middle estimate and measured number coincide at the digits printed; measured number inside the range.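

In this assay, methoxy in place of hydrogen on an aromatic carbon gives a number no higher from compound 3 to compound 4 (the limit leaves the size open). Set side by side in this assay, the two cases of methoxy in place of hydrogen on an aromatic carbon read as follows: the same change on two cores in this assay, no change at the digits printed (within the scatter) from compound 1 to compound 2 and a number no higher (the limit leaves the size open) from compound 3 to compound 4; the limit leaves it open whether they differ. Compound 3 has only a limit, > 100000 nM; the steps that start or end at it cannot be read in size, and nothing here shows whether this change behaves alike or differently on the two cores. Among these compounds, the one readable comparison around compound 4 is 2,4-dimethoxyphenyl in place of 4-chlorophenyl on a saturated ring carbon, which gives no change at the digits printed from compound 2 to compound 4 (within the scatter), so the series stays at the same printed level, and this says nothing about how the change would carry to a core with a measurable number.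

The whole set sits at the upper edge of the range, and the values there cannot separate these groups: the limit of > 100000 nM in this assay, at which 1 of the 4 values shown sits. Chloro and methoxy are the only groups on these rings, so it stays open whether an amine, a carboxylic acid or a longer chain in their place, or a change to the shared core itself, would bring a lower number in this assay.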